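A few compounds are considered here, and "the series" means these few. Any claim that something is new, unique, unknown or untested is made for them only; others in the source may bear on it.

Compound 1, `CCC(CC)C(N)CCN(C(=O)[C@@H]1C[C@H]1c1ccccc1)c1ccc(-c2ccccc2)cc1`, gives 2 nM in a functional assay for agonist activity at G protein-coupled receptor 88 (Homo sapiens), read by HTRF and cAMP accumulation; on this read-out higher numbers stand for an effect only at larger amounts of compound and lower numbers for an effect already at smaller amounts.
Compound 2, `CC[C@H](C)[C@H](N)CN(C(=O)[C@@H]1C[C@H]1c1ccccc1Cl)c1ccc(-c2ccccc2)cc1`, gives in this assay only the limit of the assay, > 25000 nM.

Compound 2 therefore stands at the limit of > 25000 nM in this assay, at which 1 of the 2 values shown sits, so no number is known for it, only that any effect would need more compound than the assay covers, while compound 1 shows an effect already at a small amount. Compound 3, `CC[C@H](C)[C@H](N)CN(C(=O)[C@@H]1C[C@H]1c1ccccc1F)c1ccc(-c2ccccc2)cc1`, has not yet been measured. It differs from compound 2 in one place: fluoro in place of chloro on an aromatic carbon. Going by the values given here, no measured pair here changes only this spot, so the size of this step cannot be read from the data, and a step of any size or none beyond the scatter is possible. Compound 3 is expected to remain weak, near compound 2, and may again reach only the limit. Compound 3 is estimated at 8000 nM, within a range from 800 nM to 25000 nM. That estimate means an expected step of an at least 3.1-fold lower number from compound 2 to compound 3 (0.49 log units; beyond the scatter).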

Compound 3, half-maximal effective concentration: 650 nM
The estimate for compound 3 lay 12-fold (1.09 log units) above the measured number, outside the stated range (below it).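

In this assay, the place on the aromatic ring ortho to a large group proves sensitive to a change of one heavy atom: fluoro in place of chloro gives an at least 38-fold lower number from compound 2 to compound 3 (1.58 log units; beyond the scatter). This step is only a minimum, because compound 2 has a limit and not a number: the limit of > 25000 nM in this assay, at which 1 of the 3 values shown sits. The change leaves the counts of hydrogen-bond donors and acceptors and the net charge as they were, yet it separates a compound with a measurable number from one held at the limit.

As far as these compounds go, what a methyl group, a methoxy group or plain hydrogen would give in the same place remains open. Also open, from the compounds shown here alone, are whether the same swap would act alike on the core of compound 1 and what lies behind a step of this size.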